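Removing one amide methyl from compound 2

The source may hold more compounds than are shown below. What is called first, only, known or untested is meant among the compounds shown, and "the series" means these compounds.

compound 1 `O=C(c1cccc(C#Cc2ccccc2Nc2ncnc3ccc(Cl)nc23)c1)N1CCNCC1`: in an assay on isolated protein for inhibition of MAP kinase-interacting serine/threonine-protein kinase 2 (Homo sapiens), read by HTRF, in the presence of a further agent that is not named here (on this read-out lower numbers stand for stronger inhibition and higher numbers for weaker inhibition), compound 1 gives 5000 nM
compound 2 `Cc1c(C(=O)N(C)C)oc2ccc(Nc3ncnc4ccc(Cl)nc34)cc12`: in this assay compound 2 gives 2200 nM

Compound 2 holds the lower of the two numbers; the value of compound 1 stands above it by a gap beyond the scatter, but the two structures are not linked by a single-site step, so nothing further is drawn from that pair. Compound 3 `CNC(=O)c1oc2ccc(Nc3ncnc4ccc(Cl)nc34)cc2c1C` differs from compound 2 by hydrogen in place of methyl on an amide-type nitrogen, dimethylcarbamoyl to methylcarbamoyl. Among the compounds with values here, no measured pair shows the effect of such a change, so the size of the step in this assay rests on no data; with nothing to lean on, the expectation is no step beyond the scatter in either direction. The estimate for compound 3 is 2000 nM, with a range from 700 nM to 6000 nM. The expected step of a 1.1-fold lower number from compound 2 to compound 3 (0.04 log units; within the scatter) therefore stays within the scatter.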

Compound 3, half-maximal inhibitory concentration: 2500 nM
Estimate against measurement, compound 3: 1.3-fold (0.10 log units) below; the measured number falls inside the stated range.
By their numbers in this assay, from the lowest: compounds 2, 3 and 1 (each within the scatter of the next, the first and the last beyond it).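

In this assay, within the data shown here, this is the first single-site step: a 1.1-fold higher number from compound 2 to compound 3 (0.06 log units; within the scatter). Dimethylcarbamoyl and methylcarbamoyl therefore cannot be told apart at this position on this read-out, a reading that rests on this one pair and this one core. No available evidence bears on why the step is this small.

The compounds shown leave open how the number responds to a longer chain such as ethyl on this amide-type nitrogen, to the unsubstituted carboxamide, or to a carboxylic acid in place of the amide. They also leave open whether hydrogen in place of methyl would give a similar step on another core.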